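Swapping Pyridylmethyl for Benzyl on a Urea Side Chain

A few compounds are considered here, and "the series" means these few. Any claim that something is new, unique, unknown or untested is made for them only; others in the source may bear on it.

Compound 1, `COc1cc(NC(C)CCCNC(=O)NC(c2ccccc2)c2ccccc2)c2ncccc2c1`: > 100000 nM in a functional assay on MCF7 cells (Homo sapiens), read by MTT assay, with a stated time of 72 h (a lower number here means a stronger inhibitor, a higher number a weaker inhibitor), a limit rather than a number.
Compound 2, `COc1cc(NC(C)CCCNC(=O)NCc2ccncc2)c2ncccc2c1`: 30000 nM in this assay.

Among the measured compounds shown here, compound 2 is the only compound here with an actual number, and it is a weak inhibitor. For compound 1 the result is only (the limit of > 100000 nM in this assay, at which 1 of the 2 values shown sits).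

Compound 3, `COc1cc(NC(C)CCCNC(=O)NCc2ccccc2)c2ncccc2c1`, has not yet been tested. It differs from compound 2 in one place: phenyl in place of pyridin-4-yl on a saturated chain carbon bound to an amide-type nitrogen. For the measured compounds named here, no measured pair shows a change of this kind, so the size of the step in this assay cannot be read from the data. Neither direction is clearly favoured, and the expected step from compound 2 to compound 3 is a 1.3-fold higher number from compound 2 to compound 3 (0.12 log units; within the scatter), which is small. Compound 3 is therefore expected to give about 40000 nM, with a likely range from 10000 nM to 150000 nM.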

Compound 3, half-maximal inhibitory concentration: 25000 nM
The estimate for compound 3 lay 1.6-fold (0.20 log units) above the measured number; measured number inside the range.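

Putting phenyl in place of pyridin-4-yl on a saturated chain carbon bound to an amide-type nitrogen gives a 1.2-fold lower number from compound 2 to compound 3 (0.08 log units; within the scatter) in this assay, so swapping this ring nitrogen for carbon does not separate the two compounds. Placing hydrogen instead of phenyl on a saturated chain carbon bound to an amide-type nitrogen and an aromatic carbon gives an at least 4.0-fold lower number from compound 1 to compound 3 (0.60 log units; beyond the scatter), the only step shown here that lies beyond the scatter. Compound 1 gives only a limit of the assay, not a number: the limit of > 100000 nM in this assay, at which 1 of the 3 values shown sits.

Still open, on these data alone, is whether an amine or a carboxylic acid on the phenyl ring of compound 3 would move the number beyond the scatter. Equally open, as far as these compounds go, is whether a longer chain carrying that phenyl ring would do so.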